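The source may report more compounds than this note shows. Statements on the series, on what has been measured and on what is new or still open speak of the compounds shown alone.

Measured so far:
compound 1, `O=c1nc2ccc(Cl)cn2cc1Cc1ccc(F)cc1C(F)(F)F`: 106000 nM
compound 2, `O=c1nc2ccc(Cl)cn2cc1Cc1ccc([N+](=O)[O-])cc1`: 940 nM

Among the compounds with values here, in a functional assay on SK-N-SH cells (Homo sapiens) for cytotoxicity, read by MTT assay, with a stated time of 24 h (a lower number here means a stronger inhibitor, a higher number a weaker inhibitor), compound 2 gives 940 nM, the lower of the two numbers known; compound 1 gives 106000 nM, a higher number by a margin well beyond the scatter. Compound 3, `O=c1nc2ccc(Cl)cn2cc1Cc1ccc(F)cc1`, has not yet been measured in this assay. It differs from compound 2 in one place: fluoro in place of nitro on an aromatic carbon. Within the data shown here, with no measured pair showing this change alone, the step from compound 2 to compound 3 is expected to be upward, toward a weaker inhibitor, and is estimated at a 9.6-fold higher number from compound 2 to compound 3 (0.98 log units; beyond the scatter). Compound 3 is therefore expected to give about 9000 nM, within a range from 2000 nM to 50000 nM.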

Compound 3, half-maximal inhibitory concentration: 9860 nM
Compound 3: the middle estimate sits 1.1-fold (0.04 log units) below what was measured; the measured number falls inside the stated range.
By their numbers in this assay, from the lowest: compound 2; then compound 3; then compound 1.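

In this assay, within the data shown here, fluoro in place of nitro on an aromatic carbon para to a large group gives a 10-fold higher number from compound 2 to compound 3 (1.02 log units; beyond the scatter), the first single-change reading at this position. Hydrogen in place of trifluoromethyl gives an 11-fold lower number from compound 1 to compound 3 (1.03 log units; beyond the scatter), so a change at a second place on the same ring also moves the number by a large step. No measurement of any property accompanies these steps.

Going by these compounds, whether an amine, a nitrile or a methoxy group at the position now holding fluoro would give a number nearer that of compound 2 or compound 3 remains open.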